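Sulfone to Sulfoxide on the Aryl Group of a Carbamate

The source may hold more compounds than are shown below. What is called first, only, known or untested is meant among the compounds shown, and "the series" means these compounds.

Measured compounds:
compound 1 `CC(C)OC(=O)N1CCC(Oc2ncnc3c2CCN3c2ccc(S(C)(=O)=O)cc2)CC1` with 126 nM
compound 2 `CCS(=O)(=O)N1CCC(Oc2ncnc3c2CCN3c2ccc(S(C)(=O)=O)cc2F)CC1` with 1580 nM

In a functional assay on CHO-K1 cells for agonist activity at Glucose-dependent insulinotropic receptor (Homo sapiens), read by a luciferase reporter, with a stated time of 5 h (on this read-out lower numbers stand for an effect already at smaller amounts and higher numbers for an effect only at larger amounts of compound), compound 1 gives 126 nM, the lowest of the two numbers in hand, while compound 2 gives 1580 nM; the gap between them lies beyond the usual scatter. Compound 2 differs from compound 1 in more than one place, so no single step can be read from that pair. Compound 3 `CC(C)OC(=O)N1CCC(Oc2ncnc3c2CCN3c2ccc([S@@+](C)[O-])c(F)c2)CC1` is not yet measured. Within the data shown here, it differs from compound 1 as follows: a group of 10 heavy atoms (7 carbon, 1 oxygen, 1 fluorine, 1 sulfur; one six-membered aromatic ring of carbon only) in place of a group of 10 heavy atoms (7 carbon, 2 oxygen, 1 sulfur; one six-membered aromatic ring of carbon only), on a nitrogen on an aromatic ring in a ring No step of this kind between measured compounds is available. The expectation therefore rests on compound 1 alone. The step of a 2.4-fold higher number from compound 1 to compound 3 (0.38 log units; beyond the scatter) is expected to be a modest rise, possibly within the scatter. The estimate for compound 3 is 300 nM, with a range from 80 nM to 1200 nM.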

Compound 3, half-maximal effective concentration: 631 nM
The estimate for compound 3 lay 2.1-fold (0.32 log units) below the measured number, within the range that was stated.
By their numbers in this assay, from the lowest: compound 1; then compound 3; then compound 2.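

In this assay, the step from the 4-(methylsulfonyl)phenyl group to the fluorinated aryl sulfoxide gives a 5.0-fold higher number from compound 1 to compound 3 (0.70 log units; beyond the scatter). Among these compounds, this is the first sign that the read-out responds to the group at this place, on a nitrogen on an aromatic ring in a ring, with the rest of the molecule held constant, and that the exchange keeps a measurable effect in the nanomolar range. Among the compounds shown here, the single step nevertheless carries several changes at once: the sulfone gives way to a sulfoxide with one defined stereocentre, and fluorine enters, so their separate shares cannot be read. Nothing in hand accounts for the size of this step. As far as these compounds go, it remains open how the opposite configuration at sulfur would read, and how a nitrile or a primary sulfonamide would compare on the same aromatic ring.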